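Swapping the 4-cyclopropylpiperazin-1-yl Group of Compound 1

This account rests on a few compounds, and the source may have more. Where it says the series, first, only, none or still open, it means among the compounds named here.

Going by the values given here, in an ADME assay on microsomes from liver (Mus musculus) for metabolic stability, read by LC-MS, with a stated time of 10 min (on this read-out higher numbers stand for a more stable compound and lower numbers for a less stable compound), compound 1 `CN(C[C@H]1Cc2c(cccc2N2CCN(C3CC3)CC2)CN1)[C@H]1CCCc2cccnc21` gives 7%, the lowest of the three numbers measured so far. Compound 2 `CN(C[C@H]1Cc2c(cccc2N2CCN(Cc3ccccn3)CC2)CN1)[C@H]1CCCc2cccnc21` gives 40.4%, and compound 3 `CN(C[C@H]1Cc2c(cccc2N2CCN(c3cccc(C(F)(F)F)c3)CC2)CN1)[C@H]1CCCc2cccnc21` gives 72.3%. Compound 4 `CN(C[C@H]1Cc2c(cccc2N2C[C@@H]3C[C@H]2CN3)CN1)[C@H]1CCCc2cccnc21` keeps the core of compound 1 but differs in one place: a group of 7 heavy atoms (5 carbon, 2 nitrogen; 2 five-membered non-aromatic rings with 1 hetero atom each) in place of a group of 9 heavy atoms (7 carbon, 2 nitrogen; one three-membered non-aromatic ring of carbon only, one six-membered non-aromatic ring with 2 hetero atoms), on an aromatic carbon. The 4-cyclopropylpiperazin-1-yl group leaves, and the entering group, which has no common name, sits on the same aromatic carbon.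

The measured steps bear on this change only indirectly. The step of a number 33.4 percentage points higher from compound 1 to compound 2 (beyond the scatter) and the step of a number 65.3 percentage points higher from compound 1 to compound 3 (beyond the scatter) each replace the cyclopropyl alone, and the step of a number 31.9 percentage points higher from compound 2 to compound 3 (beyond the scatter) also leaves the six-membered ring in place. Among the compounds with values here, no measured compound shows what happens when that ring itself is replaced. Still, both departures from the cyclopropyl of compound 1 went upward, and compound 1 at 7% has little room to fall. An upward move is therefore expected in this assay, though with less confidence than those steps might suggest. The expected step is a number 28 percentage points higher from compound 1 to compound 4 (beyond the scatter). For compound 4 the estimated value is 35%, with an expected range of 12% to 68%.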

Compound 4, percent of the compound remaining: 36.3%
Compound 4: middle estimate off by 1.3 percentage points, on the low side; the measured number falls inside the stated range.
By their numbers in this assay, from the lowest: compound 1; then compounds 4 and 2 (each within the scatter of the next); then compound 3.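

Replacing the whole 4-cyclopropylpiperazin-1-yl group, six-membered ring included, gives a number 29.3 percentage points higher from compound 1 to compound 4 (beyond the scatter) in this assay. The earlier steps shown here changed only the cyclopropyl, so this result extends the upward moves to a change that removes the ring itself, on the same aromatic carbon, and brings in a group with 1 hydrogen-bond donor where the leaving group has none. In this read-out, compound 2 at 40.4% and compound 4 at 36.3% stand within the scatter of each other, although the entering group of compound 4 has 2 five-membered non-aromatic rings and no substituent on its second nitrogen, but nothing available bears on why the number rose.

The compounds shown leave open which part of the change matters, as compound 4 alters the ring system, the loss of the cyclopropyl and the donor count together; an unsubstituted piperazine on this aromatic carbon would separate the loss of the cyclopropyl from the change of ring. Also open, going by these compounds, is how the entering group would behave with a 3-(trifluoromethyl)phenyl or an acetyl group on its free nitrogen.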